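Larger Groups on the Amide Chain of a Shared Core

The source may hold more compounds than are shown below. What is called first, only, known or untested is meant among the compounds shown, and "the series" means these compounds.

Compound 1 `CC(=O)N1CC2CC(C1)N2` and compound 2 `CCCC(=O)N1CC2CC(C1)N2` share a saturated bicyclic core carrying an amide. In an assay on SH-EP1 cells for displacement of a labelled ligand from Neuronal acetylcholine receptor; alpha4/beta2 (Homo sapiens), read by scintillation counting (on this read-out lower numbers stand for stronger inhibition and higher numbers for weaker inhibition), compound 1 gives 150 nM and compound 2 gives 14 nM. Going by the values given here, compound 2 stands lowest of the two numbers known so far, with compound 1 the nearest. Among the compounds with values here, the one step available, an 11-fold lower number from compound 1 to compound 2 (1.03 log units; beyond the scatter), came from putting ethyl in place of hydrogen on a saturated chain carbon bound to a carbonyl carbon. Compound 3 `O=C(CC1C=CCC1)N1CC2CC(C1)N2` goes further along the same line: cyclopent-2-en-1-yl in place of ethyl on a saturated chain carbon bound to a carbonyl carbon. That step bears directly on the expectation, since compound 2 already showed that a longer chain here brought an 11-fold lower number from compound 1 to compound 2 (1.03 log units; beyond the scatter). A further, bulkier group might continue that trend or might not, so in this assay compound 3 is expected at about 10 nM, between 2 nM and 60 nM, meaning an expected step of a 1.4-fold lower number from compound 2 to compound 3 (0.15 log units; within the scatter).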

Compound 3, inhibition constant: 53 nM
Beside the measured number, compound 3's estimate is 5.3-fold (0.72 log units) below it, and the stated range covers the measured number.
By their numbers in this assay, from the lowest: compound 2; then compound 3; then compound 1.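

In this assay, the trend seen so far does not simply continue with a larger group at this position: cyclopent-2-en-1-yl in place of ethyl gives a 3.8-fold higher number from compound 2 to compound 3 (0.58 log units; beyond the scatter) and so gives back part of the earlier gain. The ring still keeps an advantage over hydrogen on the same saturated chain carbon bound to a carbonyl carbon, with a 2.8-fold lower number from compound 1 to compound 3 (0.45 log units; beyond the scatter) in the same assay, so among these three compounds the ethyl group of compound 2 gives the lowest number. No measurement offered here accounts for this turn in the trend.

The three compounds cannot separate the effect of the ring, its double bond and the added carbons. Comparing a saturated cyclopentyl group, a straight pentyl chain or a propyl chain at this place would show which of these features tracks the change.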